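Removing a Methyl From an Inactive Fused Core

A few compounds are considered here, and "the series" means these few. Any claim that something is new, unique, unknown or untested is made for them only; others in the source may bear on it.

In a functional assay for inhibition, with Homo sapiens as the target (on this read-out lower numbers stand for stronger inhibition and higher numbers for weaker inhibition), compound 1, `CCCc1nc(C)c2c(C)nn(CC)c(=O)n12`, gives only a limit of the assay, > 48000 nM. Compound 3, `CCCc1nc(C)c2cnn(CC)c(=O)n12`, likewise gives only a limit in this assay, > 48000 nM. The two differ by hydrogen in place of methyl on an aromatic carbon, and between them lies a step that the two limits leave unreadable from compound 1 to compound 3. Compound 2, `CCOC(=O)CSc1nncc2c(C)ncn12`, is built on a core whose difference from the core of compound 1 is not broken down here. In this assay compound 2 also gives only a limit, > 48000 nM. All three measured values sit at the limit of > 48000 nM in this assay, at which 3 of the 3 values shown sit. Compound 4, `CCOC(=O)CSc1nncc2cncn12`, is not yet measured and differs from compound 2 by hydrogen in place of methyl on an aromatic carbon. This is the same kind of change as that from compound 1 to compound 3, though not the same one: there the place was on a six-membered aromatic ring with 3 nitrogen, here it is on a five-membered aromatic ring with 2 nitrogen. The step that the limit leaves unreadable from compound 2 to compound 4 is expected to be small. That expectation rests on compound 2, which gives only a limit in this assay, > 48000 nM. It also rests on the unreadable step that the two limits leave unreadable from compound 1 to compound 3. Compound 4 is therefore estimated at 70000 nM, between 20000 nM and 250000 nM.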

Compound 4, half-maximal inhibitory concentration: > 48000 nM
Compound 4 ended at the assay's limit; the forecaster's own chance of this, stated with the estimate: 85%; the middle value lies beyond the limit too.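

Compound 2 and compound 4 both give only a limit in this assay, so no step can be read between them: the limit of > 48000 nM in this assay, at which 4 of the 4 values shown sit.

The compounds shown leave open whether hydrogen in place of methyl on an aromatic carbon changes inhibition at all, on either core, and what change, if any, would give a readable value.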